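Trifluoromethyl in place of ethyl: expectation for compound 4

The source may report more compounds than this note shows. Statements on the series, on what has been measured and on what is new or still open speak of the compounds shown alone.

Measured in a functional assay on cells for agonist activity at G-protein coupled receptor 52 (Homo sapiens), read by AlphaScreen and cAMP accumulation, with a stated time of 30 min; a higher number here means a larger maximal response, a lower number a smaller maximal response:
compound 1 `Cc1nc(Cc2cccc(C(F)(F)F)c2)sc1-c1ccc(C(N)=O)cc1` gives 93%
compound 2 `CCc1cc(-c2sc(Cc3cccc(C(F)(F)F)c3)nc2C)ccc1C(N)=O` gives 84%
compound 3 `Cc1nc(Cc2cccc(C(F)(F)F)c2)sc1-c1ccc(C(N)=O)c(F)c1` gives 84%

Compound 2 and compound 3 report the same number and together sit lowest of the three. The step of a number 9 percentage points lower from compound 1 to compound 2 (within the scatter) lies within the scatter, as does a number 9 percentage points lower from compound 1 to compound 3 (within the scatter); the step of no change at the digits printed from compound 2 to compound 3 (within the scatter) shows no change at the digits printed.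

Compound 4 `Cc1nc(Cc2cccc(C(F)(F)F)c2)sc1-c1ccc(C(N)=O)c(C(F)(F)F)c1` differs from compound 2 by trifluoromethyl in place of ethyl on an aromatic carbon. The step that bears most directly on this change is no change at the digits printed from compound 2 to compound 3 (within the scatter), where a different group replaced ethyl at the same place without any shift; the steps of a number 9 percentage points lower from compound 1 to compound 2 (within the scatter) and a number 9 percentage points lower from compound 1 to compound 3 (within the scatter) were also within the scatter. A step of no change at the digits printed from compound 2 to compound 4 (within the scatter) in this assay is therefore expected, nothing beyond the scatter. For compound 4 the expected value is 84%, within 70% to 96%.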

Compound 4, largest response reached (Emax), in percent of the reference or control that the assay uses: 92%
Compound 4: the middle estimate sits 8 percentage points below what was measured; the measured number falls inside the stated range.
By their numbers in this assay, from the lowest: compounds 2, 3, 4 and 1 (each within the scatter of the next).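

On the aromatic carbon ortho to a carbamoyl group, trifluoromethyl now joins ethyl and fluoro, and in this assay the steps of a number 8 percentage points higher from compound 2 to compound 4 (within the scatter) and a number 8 percentage points higher from compound 3 to compound 4 (within the scatter) and a number 1 percentage points lower from compound 1 to compound 4 (within the scatter) all stay within the scatter. Across compounds 1 to 4, hydrogen, ethyl, fluoro and trifluoromethyl at this carbon are therefore not separated by the largest response reached. Nothing available offers a reason for this result. From the compounds shown here alone, whether an amine, a carboxylic acid or a methoxy group on this carbon would keep that response remains open. Only the largest response is shown, so how these four compounds compare in potency also stays open.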